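This account rests on a few compounds, and the source may have more. Where it says the series, first, only, none or still open, it means among the compounds named here.

In an assay on CHO cells for displacement of a labelled ligand from Orexin/Hypocretin receptor type 1 (Homo sapiens) (a higher number here means a weaker inhibitor, a lower number a stronger inhibitor), compound 3 `Cn1c(CCC(=O)N2CCC[C@H]2C(=O)Nc2ccccc2-c2ccccc2)nc2ccccc21` gives 15 nM, the second highest of the three numbers. Compound 2 `Cn1c(SCC(=O)N2CCC[C@H]2C(=O)Nc2ccccc2-c2ccccc2)nc2ccccc21` gives 3 nM, and a 5.0-fold higher number from compound 2 to compound 3 (0.70 log units; beyond the scatter) separates the two. Compound 1 `COc1ccccc1-c1ccccc1NC(=O)[C@@H]1CCCN1C(=O)CCc1nc2ccccc2[nH]1` gives 86 nM; it differs from compound 3 in two places, so its gap says less. Compound 4 `O=C(Nc1ccccc1-c1ccccc1)[C@@H]1CCCN1C(=O)CCc1nc2ccccc2[nH]1` differs from compound 3 by hydrogen in place of methyl on an aromatic nitrogen. Within the data shown here, no measured step isolates this change; the only related comparison is compound 1 against compound 3, where the hydrogen on an aromatic nitrogen comes together with a second change and the number is higher. A modest rise beyond the scatter is therefore expected, a 2.0-fold higher number from compound 3 to compound 4 (0.30 log units; within the scatter). Compound 4 is estimated at 30 nM, within the range 10 nM to 90 nM.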

Compound 4, inhibition constant: 40 nM
Compound 4: the middle estimate sits 1.3-fold (0.12 log units) below what was measured; the range from low to high includes it.
By their numbers in this assay, from the lowest: compound 2; then compound 3; then compound 4; then compound 1.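

Taking the methyl off the aromatic nitrogen gives a 2.7-fold higher number from compound 3 to compound 4 (0.43 log units; beyond the scatter) in this assay and so weakens binding on its own, a change earlier seen only mixed with a second one. Hydrogen in place of methoxy on an aromatic carbon gives a 2.2-fold lower number from compound 1 to compound 4 (0.33 log units; beyond the scatter) and so strengthens binding. The largest step is a 13-fold higher number from compound 2 to compound 4 (1.12 log units; beyond the scatter) with both the sulfanyl link and the methyl gone. No evidence here explains these steps. On these data alone, whether an ethyl group on that nitrogen would match methyl stays open, as does how the sulfanyl link behaves with hydrogen there.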